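The source may hold more compounds than are shown below. What is called first, only, known or untested is meant among the compounds shown, and "the series" means these compounds.

This account follows the step from compound 2 to compound 4. Compound 2, with the structure `COc1ccc(C(=O)/C=C/c2ccc(F)cc2)c2c1C=CC(C)(C)O2`, was tested in a functional assay on HCT-116 cells (Homo sapiens) for antiproliferative activity, read by MTT assay, with a stated time of 24 h (a higher number here means a weaker inhibitor, a lower number a stronger inhibitor), and there compound 2 reached only a limit of the assay, giving > 10000 nM. Compound 1, with the structure `COc1cc(OC)c(OC)cc1/C=C/C(=O)c1ccc(OC)c2c1OC(C)(C)C=C2`, was also measured; in this assay compound 1 gives the limit > 10000 nM. Compound 3, with the structure `COc1ccc(C(=O)/C=C/c2ccccc2Cl)c2c1C=CC(C)(C)O2`, sits at a limit as well, and in this assay compound 3 gives > 10000 nM.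

The step from compound 2 to compound 3, a step that the two limits leave unreadable from compound 2 to compound 3, is one whose size the two limits leave unreadable. Of all the values shown, (the limit of > 10000 nM in this assay, at which 3 of the 3 values shown sit).

Compound 4, with the structure `COc1ccc(C(=O)/C=C/c2cccc(O)c2)c2c1C=CC(C)(C)O2`, differs from compound 2 by 3-hydroxyphenyl in place of 4-fluorophenyl on a double-bonded chain carbon bound to a double-bonded chain carbon. Within the data shown here, no measured step of readable size bears on this change; the only step that starts from compound 2 cannot be read. Because (the limit of > 10000 nM in this assay, at which 3 of the 3 values shown sit), compound 4 is expected to stay at that limit in this assay too, and the step from compound 2 to compound 4 is expected to be a step that the limit leaves unreadable from compound 2 to compound 4. The estimate for compound 4 in this assay is therefore 15000 nM, with a range from 4000 nM to 60000 nM.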

Compound 4, half-maximal inhibitory concentration: > 10000 nM
Compound 4: no number, only a limit; the forecaster's own chance of this, stated with the estimate: 80%; the middle value does not contradict the limit.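

Among these compounds, compound 4 sits at a limit of the assay, as do compound 2 and compound 3, so no step among them can be read in this assay: (the limit of > 10000 nM in this assay, at which 4 of the 4 values shown sit).

The compounds shown leave open how the 4-fluorophenyl, 2-chlorophenyl and 3-hydroxyphenyl groups rank against one another, and which group, if any, would give a number in this assay rather than a limit.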